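Acetylation of a ring hydroxyl across two related cores

The source may report more compounds than this note shows. Statements on the series, on what has been measured and on what is new or still open speak of the compounds shown alone.

Measured compounds in a functional assay on HEp-2 cells (Homo sapiens) for cytotoxicity, read by MTT assay; a higher number here means that more compound is needed for the effect, a lower number that less compound is needed:
Compound 1, `C=C1C(=O)O[C@]2(C)CC[C@@H]1C[C@H](O)[C@@]1(C)CC[C@H](O1)C(=C)CC[C@H]2OC(C)=O`: compound 1 gives < 20 ug/mL, which is a limit of the assay and not a number.
Compound 2, `C=C1C(=O)O[C@]2(C)CC[C@@H]1C[C@H](OC(C)=O)[C@@]1(C)CC[C@H](O1)C(=C)CC[C@H]2OC(C)=O`: compound 2 gives < 20 ug/mL, again a limit.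
Compound 3, `C=C1C(=O)O[C@]2(C)CC[C@@H]1C[C@H](O)[C@@]1(C)CC[C@H](O1)[C@](C)(O)CCC2=O`: compound 3 gives < 20 ug/mL, also a limit.

The change from compound 1 to compound 2 is acetyl in place of hydrogen on an oxygen on a saturated carbon. Its step, a step that the two limits leave unreadable from compound 1 to compound 2, cannot be sized because of the limit of < 20 ug/mL in this assay, at which 3 of the 3 values shown sit. Compound 4, `C=C1C(=O)O[C@]2(C)CC[C@@H]1C[C@H](OC(C)=O)[C@@]1(C)CC[C@H](O1)[C@](C)(O)CCC2=O`, has not yet been measured in this assay; it carries the same change on the core of compound 3, (acetyl in place of hydrogen on an oxygen on a saturated carbon). The place of the change reads the same word for word in both pairs, so this is the same change. The difference between the core of compound 1 and the core of compound 3 is not broken down here.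

For compound 4 the step is expected to be a step that the limit leaves unreadable from compound 3 to compound 4, set beside a step that the two limits leave unreadable from compound 1 to compound 2, and this rests only on the earlier pair having produced no readable shift. Compound 4 is expected at 10 ug/mL, between 3 ug/mL and 20 ug/mL, and most probably the assay again reports only a limit.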

Compound 4, concentration for half-maximal effect: < 20 ug/mL
Compound 4 ended at the assay's limit; the forecaster's own chance of this, stated with the estimate: 80%; the middle value does not contradict the limit.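

In this assay compound 4 gives < 20 ug/mL, which is a limit and not a number. No size can be read for the change from compound 3 to compound 4, because the values share one limit: the limit of < 20 ug/mL in this assay, at which 4 of the 4 values shown sit. The compounds shown leave open what concentration any of the four needs for the effect, and whether acetyl in place of hydrogen alters it on either core.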